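This account rests on a few compounds, and the source may have more. Where it says the series, first, only, none or still open, it means among the compounds named here.

Working notes on the anilide series. The shared core, carried unchanged through the set, is seen in compound 1 `O=C(CCC(=O)OCCCCCCSc1ccc([N+](=O)[O-])c2nonc12)Nc1ccccc1`, which in an assay on isolated protein for inhibition of glutathione S-transferase P (Homo sapiens), with a stated time of 10 min (a higher number here means a weaker inhibitor, a lower number a stronger inhibitor), gives 10200 nM. Among the measured compounds shown here, compound 2 `O=C(CCC(=O)OCCCCCCSc1ccc([N+](=O)[O-])c2nonc12)Nc1ccc(C(F)(F)F)cc1` gives 5050 nM in this assay and stands at the lower of the two numbers measured so far, the only step toward it being a 2.0-fold lower number from compound 1 to compound 2 (0.31 log units; beyond the scatter).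

Compound 3 `COc1ccc(NC(=O)CCC(=O)OCCCCCCSc2ccc([N+](=O)[O-])c3nonc23)cc1OC` has not yet been measured in this assay. It differs from compound 2 by 3,4-dimethoxyphenyl in place of 4-(trifluoromethyl)phenyl on an amide-type nitrogen. For the measured compounds named here, the only measured step that bears on this change is a 2.0-fold lower number from compound 1 to compound 2 (0.31 log units; beyond the scatter), which shows that a substituent on that aromatic ring moved the number only modestly; there is no measured step for a methoxy group on this ring, so the direction of the new change is open. The step from compound 2 to compound 3 is therefore expected to be small, a 1.6-fold higher number from compound 2 to compound 3 (0.20 log units; within the scatter), possibly returning toward the number of compound 1. Compound 3 is estimated at 8000 nM, with a range from 3000 nM to 25000 nM.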

Compound 3, half-maximal inhibitory concentration: 6470 nM
Estimate against measurement, compound 3: 1.2-fold (0.09 log units) above, and the stated range covers the measured number.
By their numbers in this assay, from the lowest: compounds 2, 3 and 1 (each within the scatter of the next, the first and the last beyond it).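

Two ring changes on the amide-type nitrogen now sit within the scatter: the exchange of 4-(trifluoromethyl)phenyl for 3,4-dimethoxyphenyl (a 1.3-fold higher number from compound 2 to compound 3 (0.11 log units; within the scatter)) and the exchange of phenyl for 3,4-dimethoxyphenyl (a 1.6-fold lower number from compound 1 to compound 3 (0.20 log units; within the scatter)). In this assay the 3,4-dimethoxyphenyl anilide therefore cannot be separated from either earlier anilide, even though the two earlier anilides are separated (a 2.0-fold lower number from compound 1 to compound 2 (0.31 log units; beyond the scatter)). Two hydrogen-bond acceptors entering on this ring thus leave no readable mark on the number, and nothing available accounts for this result.

Still open, as far as these compounds go, is whether an amine or a carboxylic acid on this ring would give a step beyond the scatter. Also open, from the compounds shown here alone, is how a longer chain in place of the anilide ring would read against the shared core.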